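A few compounds are considered here, and "the series" means these few. Any claim that something is new, unique, unknown or untested is made for them only; others in the source may bear on it.

The measured compounds:
Compound 1, `Oc1ccccc1-c1cc(-c2ccccc2F)cc(-c2ccccc2O)n1`, gives in a functional assay on HCT-15 cells (Homo sapiens) for inhibition (on this read-out higher numbers stand for weaker inhibition and lower numbers for stronger inhibition), a value of > 50000 nM, which is a limit of the assay and not a number.
Compound 2, `Oc1ccccc1-c1cc(-c2cccc(F)c2)cc(-c2ccccc2O)n1`, gives in this assay > 50000 nM, again a limit.
Compound 3, `Oc1ccccc1-c1cc(-c2ccc(C(F)(F)F)cc2)cc(-c2ccccc2O)n1`, gives in this assay > 50000 nM, also a limit.

Compound 3 therefore stands at the limit where every measured value sits (the limit of > 50000 nM in this assay, at which 3 of the 3 values shown sit). No difference among the three measured compounds can be read: the step that the two limits leave unreadable from compound 1 to compound 2, the step that the two limits leave unreadable from compound 1 to compound 3 and the step that the two limits leave unreadable from compound 2 to compound 3 are all left unreadable by the two limits, so the fluorophenyl and trifluoromethylphenyl variants give no usable comparison.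

Compound 4, `Oc1cccc(-c2cc(-c3ccc(C(F)(F)F)cc3)cc(-c3ccccc3O)n2)c1`, has not yet been measured in this assay. It differs from compound 3 in one place: 3-hydroxyphenyl in place of 2-hydroxyphenyl on an aromatic carbon. Among the compounds with values here, none of the measured steps touches a hydroxyphenyl group, and none of them has a readable size, so they offer no guide to the direction or size of this change. The expected step is a step that the limit leaves unreadable from compound 3 to compound 4, with the measurement most likely returning a limit again. Compound 4 is estimated at 60000 nM, between 20000 nM and 200000 nM.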

Compound 4, half-maximal inhibitory concentration: > 50000 nM
Compound 4 was reported as a limit; the forecaster's own chance of this, stated with the estimate: 75%; the middle value is on the limit's open side.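

Compound 3 and compound 4 both sit at a limit of the assay, so the swap of 2-hydroxyphenyl for 3-hydroxyphenyl gives no readable step in this assay: the limit of > 50000 nM in this assay, at which 4 of the 4 values shown sit.

The compounds shown leave open whether any change on the shared core gives a measurable value in this assay.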